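Working notes: from compound 3 to compound 4

A few compounds are considered here, and "the series" means these few. Any claim that something is new, unique, unknown or untested is made for them only; others in the source may bear on it.

Values in an ADME assay on B16-F10 cells (Mus musculus) for cytotoxicity, read by CCK-8 assay, with a stated time of 16 h; on this read-out lower numbers stand for stronger inhibition and higher numbers for weaker inhibition:
- compound 1 `COc1ccc(C2=[N+]3C(=Nc4c(-c5ccccc5)c5c(n4[B-]3(F)F)-c3ccc(OCC(=O)O)cc3CC5)C(c3ccccc3)=C2I)cc1`: > 50000 nM
- compound 2 `COc1ccc(C2=[N+]3C(=Nc4c(-c5ccccc5)c5c(n4[B-]3(F)F)-c3ccc(OCC(=O)N[C@@H](CCC(=O)O)C(=O)O)cc3CC5)C(c3ccccc3)=C2I)cc1`: > 250000 nM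
- compound 3 `COc1ccc2c(c1)CCc1c(-c3ccccc3)c3n(c1-2)[B-](F)(F)[N+]1=C(c2ccc(OCC(=O)O)cc2)C(I)=C(c2ccccc2)C1=N3`: > 50000 nM

None of these entries is a number; each is a limit of the assay. Compound 3 stands only at a limit in this assay, namely > 50000 nM. Compound 1 and compound 3 both sit at the limit of > 50000 nM in this assay, at which 2 of the 3 values shown sit.

The unmeasured compound 4 `COc1ccc2c(c1)CCc1c(-c3ccccc3)c3n(c1-2)[B-](F)(F)[N+]1=C(c2ccc(OCC(=O)N[C@@H](CCC(=O)O)C(=O)O)cc2)C(I)=C(c2ccccc2)C1=N3` carries (1,3-dicarboxypropyl)amino in place of hydroxy on a carbonyl carbon.

The same exchange has been measured once in the series, as a step that the two limits leave unreadable from compound 1 to compound 2. Compound 2 stands at the limit of > 250000 nM in this assay, at which 1 of the 3 values shown sits, so both ends of that step are limits and no size can be carried over to compound 3. Among the measured compounds shown here, the only guide to the level of compound 4 is compound 2, whose limit is > 250000 nM.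

The expected change is a step that the limit leaves unreadable from compound 3 to compound 4, toward weaker inhibition if it can be read at all. Compound 4 is estimated at 250000 nM, with an expected range from 100000 nM to 500000 nM. A report of a limit alone is the expected outcome for this measurement.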

Compound 4, half-maximal inhibitory concentration in the B16-F10 assay: > 250000 nM
Compound 4 gave a limit, no number; the forecaster's own chance of this, stated with the estimate: 90%; the middle value lies on the limit itself.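

In the B16-F10 assay compound 3 gives > 50000 nM as a limit of the assay, not a number. In the B16-F10 assay compound 4 gives > 250000 nM as a limit of the assay, not a number. No step can be read between them. The compounds shown leave open whether (1,3-dicarboxypropyl)amino in place of hydroxy on a carbonyl carbon changes the level in the B16-F10 assay at all; all four stand at limits there. In a physicochemical assay for lipophilicity (a lower number here means a more polar compound, a higher number a more lipophilic compound), compound 3 gives 0.92 and compound 4 gives -0.71 as measured numbers.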